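The compounds below may be only part of what the source reports. "The series", "measured", "known", "first", "only" and "open" are said of these compounds alone.

Measured in an ADME assay on A549 cells (Homo sapiens) for cytotoxicity, read by LDH release, with a stated time of 15 h; a lower number here means that less compound is tolerated, a higher number that more compound is tolerated:
- compound 1 `CC1(Nc2ccc(NC(=O)c3cc(Cl)ccc3O)c(Cl)c2)CCCCC1`: 86500 nM
- compound 2 `O=C(Nc1ccc(NCC2CCNCC2)cc1Cl)c1cc(Cl)ccc1O`: "not determined" (no result reported)
- compound 3 `O=C(Nc1ccc(NC2CCCC2)cc1Cl)c1cc(Cl)ccc1O`: "not determined" (no result reported)

Compound 3 has no place on the numerical scale. Its entry in this assay carries no single number, and the same is true of compound 2. Among the compounds with values here, only compound 1 supplies a measured figure, so there is no measured step from which the effect of a change could be read.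

The next compound, compound 4 `CC(C)Nc1ccc(NC(=O)c2cc(Cl)ccc2O)c(Cl)c1`, keeps the shared core of compound 3 and alters one substituent: isopropyl in place of cyclopentyl on a nitrogen on an aromatic ring. In plain terms, isopropyl stands in place of cyclopentyl on a nitrogen on an aromatic ring, a change from cyclopentylamino to isopropylamino.

With no value for compound 3, the step itself cannot be anchored at its starting point. The expectation is therefore for no step beyond the scatter in this assay, and no direction is favoured. The best available reference is compound 1 at 86500 nM, which carries a different group on the same nitrogen, and the wide range below reflects that this is a single reference point.

For compound 4 the expected value is 60000 nM, with an estimated range from 20000 nM to 170000 nM.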

Compound 4, half-maximal cytotoxic concentration: 82700 nM
For compound 4 the middle estimate is 1.4-fold (0.14 log units) below the measured one, within the range that was stated.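

In this assay, within the data shown here, the change to isopropyl from 1-methylcyclohexyl on a nitrogen on an aromatic ring gives the first step that can be read, a 1.0-fold lower number from compound 1 to compound 4 (0.02 log units; within the scatter), so the assay does not separate these two groups at this position. The step from compound 3 to compound 4 and any step involving compound 2 cannot be read, which leaves the change from cyclopentyl to isopropyl without a measured size. No supporting measurement bears on this result.

The compounds shown leave open whether a group of a different kind on this nitrogen, such as a carboxylic acid or a longer chain, would shift the number in this assay beyond the scatter. They also leave open whether the agreement between compound 1 and compound 4 extends to other groups, since it rests on this single pair.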